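The source may hold more compounds than are shown below. What is called first, only, known or untested is meant among the compounds shown, and "the series" means these compounds.

Three compounds with a shared core have been run through an ADME assay on HepG2 2.2.15 cells (Homo sapiens) for cytotoxicity, read by MTT assay, with stated times of 48 h and 9 days (on this read-out higher numbers stand for lower toxicity in this test and lower numbers for higher toxicity in this test), so far. Compound 1 `COc1ccc(CNC(=O)/C=C/c2coc3cc(O)ccc3c2=O)cc1` gives 718000 nM in this assay. Compound 2 `COc1ccc2c(=O)c(/C=C/C(=O)Nc3ccccc3)coc2c1` gives 523000 nM in this assay. Compound 3 `COc1ccc(NC(=O)/C=C/c2coc3cc(O)ccc3c2=O)cc1` gives 976000 nM in this assay. Among these three figures the one for compound 2 is numerically the smallest, yet its gaps to compound 1 and to compound 3 both fall within the usual scatter of repeated measurements, so the three compounds cannot be told apart on this read-out; all three sit at the low-toxicity end of the scale.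

Compound 4 `COc1ccc2c(=O)c(/C=C/C(=O)NCc3ccc(C)cc3)coc2c1` has not yet been measured in this assay. It differs from compound 2 in one place: 4-methylbenzyl in place of phenyl on an amide-type nitrogen. Among the compounds with values here, no pair of measured compounds differs by exactly this change, so there is no measured step to lean on. What the three measured compounds do show is that swapping the group on the amide-type nitrogen, from a benzyl-type group in compound 1 to phenyl-type groups in compound 2 and compound 3, leaves the read-out within the scatter.

On that basis the step of a 1.2-fold higher number from compound 2 to compound 4 (0.09 log units; within the scatter) is expected to be small, with no direction beyond the scatter. Compound 4 is therefore estimated at 650000 nM in this assay, in a range from 300000 nM to 1400000 nM.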

Compound 4, half-maximal cytotoxic concentration: 257000 nM
Beside the measured number, compound 4's estimate is 2.5-fold (0.40 log units) above it; measured number outside the range, below it.
By their numbers in this assay, from the lowest: compound 4; then compounds 2, 1 and 3 (each within the scatter of the next).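

In this assay, within the data shown here, the group on the amide-type nitrogen proves able to move the read-out: putting 4-methylbenzyl in place of phenyl gives a 2.0-fold lower number from compound 2 to compound 4 (0.31 log units; beyond the scatter), a modest change, but the first measured step here that lies beyond the scatter, and in the direction of higher toxicity in this test. The shift comes with no change in the counted features of the group, since phenyl and 4-methylbenzyl each hold one six-membered aromatic ring of carbon only, with no hydrogen-bond donors or acceptors and no net charge, so only the added carbon differs. Nothing measured here explains why the number falls.

On these data alone, this single step cannot separate the benzyl part of the new group from its methyl, so it remains open whether plain benzyl would give a number like that of compound 2 or like that of compound 4. Also open, as far as these compounds go, is how the read-out would respond to a longer chain, such as phenethyl, or to an amine or a carboxylic acid on the group at this nitrogen.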